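A few compounds are considered here, and "the series" means these few. Any claim that something is new, unique, unknown or untested is made for them only; others in the source may bear on it.

Compound 1 `CCOC(=O)C1=CCCCC1S(=O)(=O)Cc1cccc(Cl)c1` gives 14 nM in a functional assay on RAW264.7 cells (Mus musculus), read by fluorescence; a lower number here means a stronger inhibitor, a higher number a weaker inhibitor.
Compound 2 `COC(=O)C1=CCCCC1S(=O)(=O)Cc1ccc(F)cc1Cl` gives 99 nM in this assay.
Compound 3 `CC(C)OC(=O)C1=CCCCC1S(=O)(=O)Cc1ccc(F)cc1Cl` gives 100 nM in this assay.

Compound 3 stands highest of the three numbers in this assay; compound 2 sits within the scatter of it, while compound 1 lies furthest away with a clearly lower number. Compound 4 `CCC(O)C1=CCCCC1S(=O)(=O)Cc1ccc(F)cc1Cl` differs from compound 3 in one place: 1-hydroxypropyl in place of isopropoxycarbonyl on a double-bonded ring carbon. For the measured compounds named here, the only measured step, a 1.0-fold higher number from compound 2 to compound 3 (0.00 log units; within the scatter), concerns isopropyl in place of methyl on an oxygen next to a carbonyl group and so bears little on exchanging the whole ester for an alcohol. Going by the values given here, no measured pair shows such an exchange, so the expectation rests on the extent of the change alone. Compound 4 is expected to give a weaker result, a 4.0-fold higher number from compound 3 to compound 4 (0.60 log units; beyond the scatter), with an estimate of 400 nM and a wide range from 80 nM to 3000 nM in this assay.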

Compound 4, half-maximal inhibitory concentration: > 10000 nM
Compound 4: a limit, no number; the forecaster's own chance of this, stated with the estimate: 20%; middle value at least 25-fold (1.39 log units) away from the limit.
By their numbers in this assay, from the lowest: compound 1; then compounds 2 and 3 (each within the scatter of the next). At a limit, above all of these: compound 4.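

In this assay compound 4 gives only a limit of the assay, not a number: the limit of > 10000 nM in this assay, at which 1 of the 4 values shown sits. Where swapping methyl for isopropyl on the ester oxygen left the number within the scatter, replacing the ester itself on the double-bonded ring carbon has a large effect, with an at least 100-fold higher number from compound 3 to compound 4 (2.00 log units; beyond the scatter) and likewise an at least 100-fold higher number from compound 2 to compound 4 (2.00 log units; beyond the scatter). This position therefore tolerates changes to the alkyl part of the ester far better than loss of the ester. From the compounds shown here alone, whether an amide or a carboxylic acid on this carbon would keep the activity remains open. So does whether a ketone carrying the same chain would behave like the esters or like compound 4.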